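The source may hold more compounds than are shown below. What is called first, only, known or untested is meant among the compounds shown, and "the series" means these compounds.

Compound 1 `CCc1ccccc1-n1nncc1CN1C(=O)C2(C(C#N)=C(N)Oc3c(N)cc4nc5ccccc5nc4c32)c2ccccc21` is the starting point of this set. In a functional assay on MCF7 cells (Homo sapiens) for antiproliferative activity, read by MTT assay, with a stated time of 48 h (a lower number here means a stronger inhibitor, a higher number a weaker inhibitor), compound 1 gives 24600 nM, already a weak inhibitor. Compound 2 `Cc1cc(C)cc(-n2nncc2CN2C(=O)C3(C(C#N)=C(N)Oc4c(N)cc5nc6ccccc6nc5c43)c3ccccc32)c1` carries 3,5-dimethylphenyl on the aromatic nitrogen in place of 2-ethylphenyl. In this assay compound 2 reaches only a limit of the assay, > 50000 nM. Compound 3 `N#CC1=C(N)Oc2c(N)cc3nc4ccccc4nc3c2C12C(=O)N(Cc1cnnn1-c1c(F)cccc1F)c1ccccc12` carries 2,6-difluorophenyl at the same place. In this assay compound 3 likewise reaches only a limit, > 50000 nM. Compound 3 thus stands at the limit of > 50000 nM in this assay, at which 2 of the 3 values shown sit, with no number of its own. The step of an at least 2.0-fold higher number from compound 1 to compound 3 (0.30 log units; that floor lies within the scatter) and the step that the two limits leave unreadable from compound 2 to compound 3 show how little these aryl swaps have revealed so far.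

Compound 4 `COc1cc(-n2nncc2CN2C(=O)C3(C(C#N)=C(N)Oc4c(N)cc5nc6ccccc6nc5c43)c3ccccc32)c(OC)cc1Cl` changes the aryl group once more: 4-chloro-2,5-dimethoxyphenyl in place of 2,6-difluorophenyl on an aromatic nitrogen. The two steps that bear on this change are an at least 2.0-fold higher number from compound 1 to compound 3 (0.30 log units; that floor lies within the scatter) and a step that the two limits leave unreadable from compound 2 to compound 3, neither of which gives a readable size, so no movement beyond the scatter can be expected in this assay, and a further limit is the likeliest outcome. For compound 4 the expected value is therefore 45000 nM, between 15000 nM and 100000 nM. That estimate for compound 4 corresponds to an at least 1.1-fold lower number from compound 3 to compound 4 (0.04 log units; that floor lies within the scatter).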

Compound 4, half-maximal inhibitory concentration: > 50000 nM
Compound 4: no number, only a limit; the forecaster's own chance of this, stated with the estimate: 65%; middle value at least 1.1-fold (0.04 log units) away from the limit.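

With more heavy atoms than 2,6-difluorophenyl, and with hydrogen-bond acceptors that it lacks, 4-chloro-2,5-dimethoxyphenyl still yields no number in this assay, so three differently substituted aryl groups at this position now end at a limit of the assay: the limit of > 50000 nM in this assay, at which 3 of the 4 values shown sit.

Both ends of the steps from compound 2 and from compound 3 to compound 4 are limits, and those steps cannot be read. Only compound 1, with 2-ethylphenyl, goes against this run, and the comparison with it gives an at least 2.0-fold higher number from compound 1 to compound 4 (0.30 log units; that floor lies within the scatter), so even this gap is not shown to exceed the scatter.

From the compounds shown here alone, it remains open whether an aryl group carrying an amine or a carboxylic acid would give a measurable value here. The same holds for a longer chain in place of the aryl group, and for how far the value of compound 1 can be improved at all.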